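Bicyclic amine in place of cyclohexyl on the quinoline core

The source may report more compounds than this note shows. Statements on the series, on what has been measured and on what is new or still open speak of the compounds shown alone.

Compound 1 `COc1ccc(Cl)cc1C(=O)NCCC1CCN(S(=O)(=O)NC(=O)NC2CCCCC2)CC1` gives 25% in a functional assay on the whole organism (blood) with Rattus norvegicus as the target, with stated times of 24 h and 1 h, at a dose of 5 mg/kg by the intraperitoneal route; a lower number here means a weaker effect, a higher number a stronger effect of the compound at the dose given. Compound 2 `COc1ccc(Cl)cc1C(=O)NCCC1CCN(S(=O)(=O)NC(=O)NC[C@@H]2C[C@@H]3C=C[C@@H]2C3)CC1` gives 37% in this assay; the change a group of 8 heavy atoms (8 carbon; 2 five-membered non-aromatic rings of carbon only) in place of a group of 6 heavy atoms (6 carbon; one six-membered non-aromatic ring of carbon only), on an amide-type nitrogen made a step of a number 12 percentage points higher from compound 1 to compound 2 (beyond the scatter). Compound 3 `O=C(NC1CCCCC1)NS(=O)(=O)N1CCC(CCNC(=O)c2ccc3ccccc3n2)CC1` gives 11% in this assay, the lowest of the three numbers; it differs from compound 1 by quinolin-2-yl in place of 5-chloro-2-methoxyphenyl on a carbonyl carbon, a step of a number 14 percentage points lower from compound 1 to compound 3 (beyond the scatter). Compound 4 `O=C(NC[C@@H]1C[C@@H]2C=C[C@@H]1C2)NS(=O)(=O)N1CCC(CCNC(=O)c2ccc3ccccc3n2)CC1` carries the same change on the core of compound 3: a group of 8 heavy atoms (8 carbon; 2 five-membered non-aromatic rings of carbon only) in place of a group of 6 heavy atoms (6 carbon; one six-membered non-aromatic ring of carbon only), on an amide-type nitrogen, seen once before, from compound 1 to compound 2, with both places described in the same words. The expectation is a step of about a number 12 percentage points higher from compound 3 to compound 4 (beyond the scatter) in this assay, resting on the earlier step of a number 12 percentage points higher from compound 1 to compound 2 (beyond the scatter) and on the starting value of compound 3 11%. Compound 4 is thus estimated at 23% in this assay, expected to lie between 10% and 36%.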

Compound 4, a percentage reported as activity, at one dose (the size of the read-out at that dose, not a potency): 21%
The estimate for compound 4 lay 2 percentage points above the measured number; measured number inside the range.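

In this assay, the group of 8 heavy atoms in place of cyclohexyl on the amide-type nitrogen gives a step of a number 10 percentage points higher from compound 3 to compound 4 (within the scatter), which agrees with the earlier step on the core of compound 1: the same change on two cores in this assay, a number 12 percentage points higher (beyond the scatter) from compound 1 to compound 2 and a number 10 percentage points higher (within the scatter) from compound 3 to compound 4, 2 percentage points apart, within the scatter of two such steps The quinolin-2-yl change, read on the other pair, gives a step of a number 16 percentage points lower from compound 2 to compound 4 (beyond the scatter) and also agrees with its earlier counterpart: the same change on two cores in this assay, a number 14 percentage points lower (beyond the scatter) from compound 1 to compound 3 and a number 16 percentage points lower (beyond the scatter) from compound 2 to compound 4, 2 percentage points apart, within the scatter of two such steps The two changes therefore carry over consistently across these four compounds, but the step on the core of compound 3 does not stand clear of the scatter on its own, and two cores at one dose establish no general rule.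

On these data alone, it remains open which feature of the entering group goes with the step. A cyclohexylmethyl group, or the same bicyclic group without its double bond, would separate these features.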